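Chain extension at the ring-bound amine: first estimate

This account rests on a few compounds, and the source may have more. Where it says the series, first, only, none or still open, it means among the compounds named here.

Compound 1 `CNc1nc2cc(Cl)c(Cl)cc2n1[C@@H]1O[C@@H](CO)[C@@H](O)[C@H]1O` — in a functional assay on KB cells (Homo sapiens) for inhibition (on this read-out higher numbers stand for weaker inhibition and lower numbers for stronger inhibition), compound 1 gives > 100000 nM, a limit of the assay.
Compound 2 `CNc1nc2cc(Cl)c(Cl)cc2n1[C@@H]1O[C@H](CO)[C@@H](O)[C@H]1O` — in this assay compound 2 gives > 100000 nM, also a limit.
Compound 3 `C[C@H]1O[C@@H](n2c(Br)nc3cc(Cl)c(Cl)cc32)[C@H](O)[C@@H]1O` — in this assay compound 3 gives > 100000 nM, also a limit.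

Compound 1 therefore stands only at a limit in this assay, and every other value shown is a limit as well. For the measured compounds named here, the single step between measured neighbours, a step that the two limits leave unreadable from compound 1 to compound 2, stays unreadable because of the limit of > 100000 nM in this assay, at which 3 of the 3 values shown sit, although the fact that compounds 1 and 2 differ only in the configuration as drawn marks it as a pure change of configuration.

Compound 4 `CCCNc1nc2cc(Cl)c(Cl)cc2n1[C@@H]1O[C@@H](CO)[C@@H](O)[C@H]1O` differs from compound 1 by ethyl in place of hydrogen on a saturated chain carbon bound to a nitrogen on an aromatic ring. Going by the values given here, no measured step bears on this change, so the numbers give no direction. The expected step is a number no higher from compound 1 to compound 4 (the limit leaves the size open), no larger than the scatter. Compound 4 is estimated at 100000 nM, between 30000 nM and 300000 nM, most likely again reported as a limit.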

Compound 4, half-maximal inhibitory concentration: > 100000 nM
Compound 4 ended at the assay's limit; the forecaster's own chance of this, stated with the estimate: 85%; the middle value sits exactly at the limit.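

No step can be read from compound 1 to compound 4 because both stand at a limit, not a number: the limit of > 100000 nM in this assay, at which 4 of the 4 values shown sit.

The compounds shown leave open whether any change to the shared core gives a readable value in this assay.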